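This account rests on a few compounds, and the source may have more. Where it says the series, first, only, none or still open, it means among the compounds named here.

Measured so far in an in vitro ADME assay on the whole organism (microsomes, liver, Mus musculus) for metabolic stability, read by LC-MS, with a stated time of 24 h, at a dose of 5 mg/kg by the intravenous route; on this read-out higher numbers stand for fast clearance and lower numbers for slow clearance:
compound 1, `O=[N+]([O-])c1cn2c(n1)OC[C@@H](NCc1ccc(OC(F)(F)F)c(F)c1)C2`, gives 58.7 mL.min-1.g-1
compound 2, `O=[N+]([O-])c1cn2c(n1)OC[C@@H](NCc1ccc(OC(F)(F)F)cc1F)C2`, gives 95.6 mL.min-1.g-1
compound 3, `CC(C)N(Cc1ccc(OC(F)(F)F)cc1)[C@@H]1COc2nc([N+](=O)[O-])cn2C1`, gives 433 mL.min-1.g-1

Compound 1 sits at the low end of the three numbers in this assay. Compound 2 lies within the usual scatter of it, so the two cannot be told apart on this read-out. Compound 3 lies well beyond the scatter, with a much higher number than compound 1 and compound 2. No pair of these compounds differs in a single place, so no measured step is available to lean on.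

The next compound, compound 4, is `O=[N+]([O-])c1cn2c(n1)OC[C@@H](NCc1ccc(OC(F)(F)F)c(Oc3ccccc3)c1)C2`. It differs from compound 1 as follows: phenoxy in place of fluoro on an aromatic carbon. Among the compounds with values here, the group that enters is far larger than the one that leaves, and the series gives no measured pair that isolates a change of this kind.

Within the data shown here, with no matching step to draw on, the expectation for compound 4 rests on the range of the three numbers alone. The step from compound 1 is expected to be upward, a 2.6-fold higher number from compound 1 to compound 4 (0.41 log units; beyond the scatter), most likely beyond the scatter but with wide uncertainty. Compound 4 is therefore estimated at 150 mL.min-1.g-1 in this assay, with a range from 60 mL.min-1.g-1 to 400 mL.min-1.g-1.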

Compound 4, intrinsic clearance in microsomes in the liver assay: 149 mL.min-1.g-1
Compound 4: the middle estimate sits 1.0-fold (0.00 log units) above what was measured, and the stated range covers the measured number.
By their numbers in the liver assay, from the lowest: compounds 1, 2 and 4 (each within the scatter of the next, the first and the last beyond it); then compound 3.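

In the liver assay, phenoxy in place of fluoro on the aromatic carbon ortho to a trifluoromethoxy group gives a 2.5-fold higher number from compound 1 to compound 4 (0.40 log units; beyond the scatter), a modest step for so large an entering group, while in a physicochemical assay for solubility, at pH 6.8 (on this read-out higher numbers stand for higher solubility and lower numbers for lower solubility), the same change gives an at least 21-fold lower number from compound 1 to compound 4 (1.33 log units; beyond the scatter), so the larger cost of this change at this position appears in solubility rather than in clearance. In the physicochemical assay compound 1 gives 43 ug/mL. In the physicochemical assay compound 4 gives < 2 ug/mL, which is a limit of the assay and not a number.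

With a single change at this position, the compounds shown cannot separate the part played by the phenyl ring from that of the linking oxygen in phenoxy. Also open, on these data alone, is whether a methoxy group at this carbon, or an amine on the entering phenyl ring, would give a different balance between the two read-outs.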